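The compounds below may be only part of what the source reports. "The series", "measured", "known", "first", "only" and "open" are said of these compounds alone.

Working notes on the series. Compound 3 is `COc1ccc(-c2cnc(NC(=O)C3CCNCC3)n2C)cc1` and compound 1 `COc1ccc(-c2cnc(NC(=O)C3CCCCC3)n2C)cc1` and compound 2 `COc1ccc(-c2cnc(NC(=O)c3ccc(Br)cc3)n2C)cc1` share its core, differing only in the group on the carbonyl carbon. In a toxicity assay on THP-1 cells (Homo sapiens) for inhibition (a higher number here means that more compound is tolerated, a lower number that less compound is tolerated), compound 1 gives > 100000 nM and this is a limit of the assay, not a number. In this assay compound 2 gives > 100000 nM which is again a limit. In this assay compound 3 gives > 100000 nM which is also a limit. Compound 3 thus stands at the same limit as the other two and has only a limit, no number. The measured steps a step that the two limits leave unreadable from compound 1 to compound 2 and a step that the two limits leave unreadable from compound 1 to compound 3 and a step that the two limits leave unreadable from compound 2 to compound 3 cannot be sized, since all three values sit at the limit of > 100000 nM in this assay, at which 3 of the 3 values shown sit, and no direction can be read.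

Compound 4 is `COc1ccc(-c2cnc(NC(=O)c3ccncc3)n2C)cc1` and the change from compound 3 is pyridin-4-yl in place of piperidin-4-yl on a carbonyl carbon on the carbonyl carbon. Within the data shown here, no measured step bears on this change in a readable way; what the three compounds show is that cyclohexyl, 4-bromophenyl and piperidin-4-yl on the carbonyl carbon all leave the compound at the limit. The step from compound 3 to compound 4 is expected to be a number no higher from compound 3 to compound 4 (the limit leaves the size open) and thus none beyond the scatter, most likely again a limit. Compound 4 is estimated at 100000 nM within a range from 50000 nM to 200000 nM in this assay.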

Compound 4, half-maximal cytotoxic concentration: > 100000 nM
Compound 4: no number, only a limit (the forecaster's own chance of this, stated with the estimate: 80%); the middle value sits exactly at the limit.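

Among these compounds, compound 4 joins compound 1, compound 2 and compound 3 at a limit, not a number, so no step among the four can be read: the limit of > 100000 nM in this assay, at which 4 of the 4 values shown sit.

The compounds shown leave open at which concentration any of them becomes toxic to these cells, and whether the group on the carbonyl carbon changes that concentration.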